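A few compounds are considered here, and "the series" means these few. Any claim that something is new, unique, unknown or untested is made for them only; others in the source may bear on it.

Measured so far in a functional assay on the whole organism with Rattus norvegicus as the target; a higher number here means that more compound is needed for the effect, a lower number that less compound is needed:
compound 1 `CC1CCC(=NNc2ccccc2)c2ncc(C(=O)O)c(=O)n21` gives 1.2 umol/kg;
compound 2 `Cc1cc(C)cc(NN=C2CCC(C)n3c2ncc(C(=O)O)c3=O)c1` gives only a limit of the assay, > 320 umol/kg;
compound 3 `CC1CCC(=NNc2ccc(Cl)c(Cl)c2)c2ncc(C(=O)O)c(=O)n21` gives only a limit of the assay, > 100 umol/kg.

Compound 3 therefore stands at a limit rather than at a number, and one further value among the three, that of compound 2, is also a limit (the limit of > 320 umol/kg in this assay, at which 1 of the 3 values shown sits). Compound 4 `Cc1cc(NN=C2CCC(C)n3c2ncc(C(=O)O)c3=O)ccc1Br` differs from compound 3 by 4-bromo-3-methylphenyl in place of 3,4-dichlorophenyl on an amine nitrogen. For the measured compounds named here, the steps that bear on this are an at least 260-fold higher number from compound 1 to compound 2 (2.42 log units; beyond the scatter) and an at least 83-fold higher number from compound 1 to compound 3 (1.92 log units; beyond the scatter), both large and both ending at a limit; between them, a step that the two limits leave unreadable from compound 2 to compound 3. In both measured steps a phenyl carrying two substituents led to a limit, and compound 4 carries a third such phenyl, so no step beyond the scatter is expected and a limit is the likely outcome. Compound 4 is therefore estimated at 200 umol/kg, with a range from 30 umol/kg to 1000 umol/kg, which means an expected step that the limit leaves unreadable from compound 3 to compound 4.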

Compound 4, dose for 50% inhibition: > 100 umol/kg
Compound 4: a limit, no number (the forecaster's own chance of this, stated with the estimate: 75%); the middle value does not contradict the limit.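

Compound 4 with its 4-bromo-3-methylphenyl also stands at a limit and not at a number: the limit of > 100 umol/kg in this assay, at which 2 of the 4 values shown sit. In this assay the change on the amine nitrogen gives an at least 83-fold higher number from compound 1 to compound 4 (1.92 log units; beyond the scatter), so a phenyl carrying bromine and methyl joins the 3,5-dimethylphenyl of compound 2 and the 3,4-dichlorophenyl of compound 3, and the plain phenyl of compound 1 alone keeps a number. The steps among compound 2, compound 3 and compound 4 cannot be read.

As far as these compounds go, how these three substituted phenyls rank remains open. So does how a phenyl carrying a single chlorine or a single methyl would read.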